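The compounds below may be only part of what the source reports. "The series", "measured", "known", "first", "only" and "open" are said of these compounds alone.

Compound 1: `Cc1ccc(S(=O)(=O)n2cc(CN(Cc3cn(Cc4ccc(F)cc4)nn3)S(C)(=O)=O)c3ccccc32)cc1`; in a functional assay on 3T3-L1 cells (Mus musculus) for inhibition, with a stated time of 20 min, tested at 20 uM (a higher number here means more inhibition at the concentration tested (going by the name of the read-out), a lower number less inhibition), compound 1 gives -19.5%.
Compound 2: `O=S(=O)(c1ccc(F)cc1)N(Cc1cccc(F)c1F)Cc1cn(S(=O)(=O)c2ccc(F)cc2)c2ccccc12`; in this assay compound 2 gives -20%.

Both measured compounds share a core and carry the same kind of sulfonyl group on the indole-type nitrogen, and both return a negative percentage in this assay, that is, no inhibition at the tested concentration. Compound 2 and compound 1 lie within the scatter of each other, so the two numbers cannot be told apart and neither compound stands out.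

Compound 3 is `O=C(N(Cc1cccc(F)c1F)Cc1cn(S(=O)(=O)c2ccc(F)cc2)c2ccccc12)C(F)(F)F`. It differs from compound 2 in one place: (trifluoromethyl)carbonyl in place of (4-fluorophenyl)sulfonyl on an amine nitrogen. Within the data shown here, no step between two measured compounds covers a change of this kind, so nothing in the data points in a particular direction. Among the measured compounds shown here, the only guidance is that compound 2 shows no inhibition, and a change at the amine nitrogen has no measured precedent here. The step from compound 2 to compound 3 is therefore expected to be small, a number 10 percentage points higher from compound 2 to compound 3 (within the scatter), not beyond the scatter in either direction. For compound 3 the expected value in this assay is -10%, within a range from -35% to 20%.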

Compound 3, a percentage reported as inhibition, at one concentration (the size of the read-out at that concentration, not a potency): -52.3%
The estimate for compound 3 lay 42.3 percentage points above the measured number; the measured number lies below the stated range.
By their numbers in this assay, from the lowest: compound 3; then compounds 2 and 1 (each within the scatter of the next).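

In this assay, (trifluoromethyl)carbonyl in place of (4-fluorophenyl)sulfonyl on an amine nitrogen whose other neighbours are saturated chain carbons gives a number 32.3 percentage points lower from compound 2 to compound 3 (beyond the scatter), so the read-out responds to what sits at this position. Among these compounds, the earlier pair could not show this, since those two compounds differ in more than one place and gave no step to read. The change moves the number further into negative values, away from inhibition, with compound 3 at -52.3%, and the data offer no explanation for the direction or size of this step.

Going by these compounds, this single step replaces a sulfonyl-linked aryl group with a carbonyl-linked trifluoromethyl group in one exchange, so it remains open whether the shift follows the loss of the (4-fluorophenyl)sulfonyl or the arrival of the (trifluoromethyl)carbonyl. On these data alone, an acetyl group or a methylsulfonyl group on the same nitrogen would help separate the two, and a free secondary amine there would show whether this nitrogen needs any such group, while whether any group at this position yields a positive inhibition value is also still open.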